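The compounds below may be only part of what the source reports. "The series", "measured", "known", "first", "only" and "open" are said of these compounds alone.

Compound 1 `O=C(c1cccc(F)c1)N1CC(c2nc(-c3cccc(Cl)c3)no2)C1` is the stronger of the two compounds with a number in an assay on HEK293 cells for negative allosteric modulation of metabotropic glutamate receptor 5 (Homo sapiens), read by FLIPR (a lower number here means a stronger inhibitor, a higher number a weaker inhibitor), giving 780 nM. Compound 2 `Cc1cccc(-c2noc(C3CN(C(=O)c4cccc(F)c4)C3)n2)c1` gives 2100 nM in this assay, and the step of a 2.7-fold higher number from compound 1 to compound 2 (0.43 log units; beyond the scatter) is a modest loss. Compound 3 `O=C(c1ccc(F)cc1)N1CC(c2nc(-c3cccc(F)c3)no2)C1` reaches only a limit of this assay, > 10000 nM, and (the limit of > 10000 nM in this assay, at which 1 of the 3 values shown sits).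

Compound 4 `CC1CN(C(=O)N2CC(c3nc(-c4cccc(Cl)c4)no3)C2)CC(C)O1` differs from compound 1 in a single place: 2,6-dimethylmorpholin-4-yl in place of 3-fluorophenyl on a carbonyl carbon. Going by the values given here, no measured step touches the group on the carbonyl carbon, since the one measured step alters a substituent elsewhere, so there is nothing to scale the change by. Swapping an aromatic ring for a saturated one here is a larger change than that step, and a weaker outcome is expected, estimated at a 3.2-fold higher number from compound 1 to compound 4 (0.51 log units; beyond the scatter). Compound 4 is therefore estimated at 2500 nM, within 600 nM to 10000 nM.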

Compound 4, half-maximal inhibitory concentration: 990 nM
Compound 4: the middle estimate sits 2.5-fold (0.40 log units) above what was measured, within the range that was stated.
By their numbers in this assay, from the lowest: compounds 1 and 4 (each within the scatter of the next); then compound 2. At a limit, above all of these: compound 3.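

In this assay, the aromatic 3-fluorophenyl on the carbonyl carbon gives way to the non-aromatic 2,6-dimethylmorpholin-4-yl with a 1.3-fold higher number from compound 1 to compound 4 (0.10 log units; within the scatter). Going by these compounds alone, the earlier compounds all carried a fluorinated aromatic ring at this place, so only this pair shows that inhibition of this size does not depend on an aromatic ring there. Nothing in the data explains why these two different groups give such similar numbers.

From the compounds shown here alone, whether morpholine without its two methyl groups, or an open-chain amine such as diethylamine, would do the same remains open.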